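Working notes on compound 4: aryl swap on the carbonyl

The source may report more compounds than this note shows. Statements on the series, on what has been measured and on what is new or still open speak of the compounds shown alone.

Values in a toxicity assay on WI-38 cells (Homo sapiens) for cytotoxicity, read by MTT assay, with a stated time of 48 h; on this read-out higher numbers stand for weaker inhibition and lower numbers for stronger inhibition:
compound 1 `O=C(/C=C/c1ccc2c(c1)B(O)OC2)c1ccccc1` – 19100 nM
compound 2 `O=C(/C=C/c1ccc2c(c1)B(O)OC2)c1cccnc1` – 76200 nM
compound 3 `Cn1cccc1C(=O)/C=C/c1ccc2c(c1)B(O)OC2` – > 100000 nM

Compound 3 stands only as a limit: its entry is the assay limit of > 100000 nM in this assay, at which 1 of the 3 values shown sits, and not a number. Compound 4 `O=C(/C=C/c1ccc2c(c1)B(O)OC2)c1ccc(Br)cc1` differs from compound 3 by 4-bromophenyl in place of 1-methyl-1H-pyrrol-2-yl on a carbonyl carbon. The measured steps that bear on this change run in the opposite direction: an at least 5.2-fold higher number from compound 1 to compound 3 (0.71 log units; beyond the scatter) and an at least 1.3-fold higher number from compound 2 to compound 3 (0.11 log units; that floor lies within the scatter). Returning from 1-methyl-1H-pyrrol-2-yl to a six-membered carbon ring is therefore expected to lower the number in this assay by at least a modest step. Because compound 1 gives 19100 nM, compound 4 is expected at an estimated 15000 nM, with a range from 5000 nM to 60000 nM. The expected step of an at least 6.6-fold lower number from compound 3 to compound 4 (0.82 log units; beyond the scatter) can only be read as a lower bound, since compound 3 is a limit.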

Compound 4, half-maximal inhibitory concentration: 36700 nM
Beside the measured number, compound 4's estimate is 2.4-fold (0.39 log units) below it; the range from low to high includes it.
By their numbers in this assay, from the lowest: compounds 1 and 4 (each within the scatter of the next); then compound 2. At a limit, above all of these: compound 3.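

Bromo in place of hydrogen on an aromatic carbon gives no separable difference in this assay: a 1.9-fold higher number from compound 1 to compound 4 (0.28 log units; within the scatter). With a substituent on the six-membered carbon ring, the aryl on the carbonyl carbon still separates from pyridin-3-yl, at a 2.1-fold lower number from compound 2 to compound 4 (0.32 log units; beyond the scatter), and from 1-methyl-1H-pyrrol-2-yl, at an at least 2.7-fold lower number from compound 3 to compound 4 (0.43 log units; beyond the scatter). That last step is only a floor, as compound 3 is a limit: the limit of > 100000 nM in this assay, at which 1 of the 4 values shown sits.

Open, on these data alone, is how an amine or a carboxylic acid in place of the bromo of 4-bromophenyl would read in this assay.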